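Changing one nitrogen group on compound 3

The compounds below may be only part of what the source reports. "The series", "measured", "known", "first", "only" and "open" are said of these compounds alone.

In a functional assay on MCF7 cells (Homo sapiens) for antiproliferative activity, read by CCK-8 assay, with a stated time of 48 h (a lower number here means a stronger inhibitor, a higher number a weaker inhibitor), compound 1 `C/C=C/C(=O)N1CC(Oc2ccc(Oc3c(-c4ccc(F)cc4)sc4cc(O)ccc34)cc2)C1` gives 28000 nM, compound 2 `C/C=C/C(=O)NCCOc1ccc(Oc2c(-c3ccc(F)cc3)sc3cc(O)ccc23)cc1` gives 21700 nM and compound 3 `CN(C)C(=O)/C=C/CN1CC(Oc2ccc(Oc3c(-c4ccc(F)cc4)sc4cc(O)ccc34)cc2)C1` gives 22300 nM. Compound 3 stands within the scatter of both others, so these three cannot be ranked. Compound 4 `C=CC(=O)N1CC(Oc2ccc(Oc3c(-c4ccc(F)cc4)sc4cc(O)ccc34)cc2)C1` keeps the rest of compound 3 and alters one place, with vinylcarbonyl in place of 3-(dimethylcarbamoyl)prop-2-en-1-yl on an amine nitrogen in a ring.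

The measured step at this same nitrogen, which swaps (prop-1-en-1-yl)carbonyl for the group that compound 4 loses, is a 1.3-fold lower number from compound 1 to compound 3 (0.10 log units; within the scatter). The other two steps, a 1.3-fold lower number from compound 1 to compound 2 (0.11 log units; within the scatter) and a 1.0-fold higher number from compound 2 to compound 3 (0.01 log units; within the scatter), are equally small. For the measured compounds named here, no compound measured so far carries vinylcarbonyl itself, but the group that compound 1 carries there has a similar name and form. Going by the values given here, since no measured step leaves the scatter, none beyond it is expected here. In this assay the expected result is a 1.1-fold lower number from compound 3 to compound 4 (0.05 log units; within the scatter). For compound 4 the estimate is 20000 nM, with an expected range from 10000 nM to 40000 nM.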

Compound 4, half-maximal inhibitory concentration: 23500 nM
Beside the measured number, compound 4's estimate is 1.2-fold (0.07 log units) below it; the measured number falls inside the stated range.
By their numbers in this assay, from the lowest: compounds 2, 3, 4 and 1 (each within the scatter of the next).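

In this assay, going from 3-(dimethylcarbamoyl)prop-2-en-1-yl, with 8 heavy atoms, to vinylcarbonyl, with 4, on the amine nitrogen in the four-membered ring gives only a step within the scatter (a 1.1-fold higher number from compound 3 to compound 4 (0.02 log units; within the scatter)). Vinyl in place of prop-1-en-1-yl on the carbonyl carbon also stays within the scatter (a 1.2-fold lower number from compound 1 to compound 4 (0.08 log units; within the scatter)), as does 1-(vinylcarbonyl)azetidin-3-yl in place of the open-chain 2-(((prop-1-en-1-yl)carbonyl)amino)ethyl (a 1.1-fold higher number from compound 2 to compound 4 (0.03 log units; within the scatter)). The smaller vinylcarbonyl group therefore adds a fourth compound that cannot be ranked against the other three. Nothing available explains why these numbers sit so close together. The compounds shown leave open whether a plain methyl, a carboxylic acid or a longer chain on this nitrogen would give a step beyond the scatter. They also leave open whether any change elsewhere on the shared core would do so.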